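This account rests on a few compounds, and the source may have more. Where it says the series, first, only, none or still open, it means among the compounds named here.

Measured so far in a functional assay on KBVIN cells (Homo sapiens) for antiproliferative activity, read by sulforhodamine B assay, with a stated time of 3 days; a lower number here means that less compound is needed, a higher number that more compound is needed for the effect:
- compound 1 `CCC1=C(O)c2c(oc(-c3ccc(O)cc3)cc2=O)C(CC)(CC)C1=O`: 20.6 uM
- compound 2 `CCC1=C(O)c2c(oc(-c3ccc(CBr)cc3)cc2=O)C(CC)(CC)C1=O`: 27.9 uM
- compound 3 `CCC1=C(O)c2c(oc(-c3ccc(OC)c(C)c3)cc2=O)C(CC)(CC)C1=O`: 0.1 uM

Compound 3 has the lowest number of the three, so it needs the least compound for the effect. Compound 4 `CCC1=C(O)c2c(oc(-c3ccc(O)c(C)c3C)cc2=O)C(CC)(CC)C1=O` is not yet measured. It carries 4-hydroxy-2,3-dimethylphenyl in place of the 4-methoxy-3-methylphenyl of compound 3, on an aromatic carbon next to the ring oxygen: 4-hydroxy-2,3-dimethylphenyl in place of 4-methoxy-3-methylphenyl on an aromatic carbon.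

The most relevant measurement is a 210-fold lower number from compound 1 to compound 3 (2.31 log units; beyond the scatter), which replaces 4-hydroxyphenyl with 4-methoxy-3-methylphenyl. Compound 4 brings back the hydroxy group of compound 1 but keeps methyl groups, so it resembles each neighbour in part. The data do not separate the contribution of the methoxy group from that of the methyl group. The other large step, a 280-fold lower number from compound 2 to compound 3 (2.45 log units; beyond the scatter), also ends at compound 3, while a 1.4-fold higher number from compound 1 to compound 2 (0.13 log units; within the scatter) shows no difference between the two weaker compounds.

A sizeable move to a higher number is therefore expected, though probably only part of the way back. The step expected in this assay is a 20-fold higher number from compound 3 to compound 4 (1.30 log units; beyond the scatter). The estimated value for compound 4 is 2 uM, with an expected range from 0.3 uM to 15 uM.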

Compound 4, concentration for half-maximal effect: 2.75 uM
For compound 4 the middle estimate is 1.4-fold (0.14 log units) below the measured one, within the range that was stated.
By their numbers in this assay, from the lowest: compound 3; then compound 4; then compounds 1 and 2 (each within the scatter of the next).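

In this assay, keeping a hydroxy group on this aryl ring does not by itself hold the number high: adding two methyl groups to the 4-hydroxyphenyl of the earlier compound gives a 7.5-fold lower number from compound 1 to compound 4 (0.87 log units; beyond the scatter) and a modest gain. The same 4-hydroxy-2,3-dimethylphenyl also improves on 4-(bromomethyl)phenyl, with a 10-fold lower number from compound 2 to compound 4 (1.01 log units; beyond the scatter) as the step, yet it falls short of 4-methoxy-3-methylphenyl, with a 28-fold higher number from compound 3 to compound 4 (1.44 log units; beyond the scatter) as the step. That last change alters the oxygen substituent and the methyl pattern together, so neither can be credited alone, and no measurement at hand explains any of these steps.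

As far as these compounds go, it remains open how 4-hydroxy-3-methylphenyl or 4-methoxy-2,3-dimethylphenyl would compare, as either would separate those two changes. An ethoxy group or an amine in place of the hydroxy group is also untested among the compounds shown.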